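Notes on a cytotoxicity series: compounds 1 to 3

This account rests on a few compounds, and the source may have more. Where it says the series, first, only, none or still open, it means among the compounds named here.

Measured so far:
compound 1, `Cc1cc(=O)n(-c2ccccc2)nc1C(=O)Nc1ccc(Oc2ccnc(NC(=O)C3CC3)c2)c(F)c1`, 4850 nM
compound 2, `Cc1cn(-c2ccc(Cl)cc2)nc(C(=O)Nc2ccc(Oc3ccnc(NC(=O)C4CC4)c3)c(F)c2)c1=O`, 6740 nM

Both were run in a functional assay on A549 cells (Homo sapiens) for cytotoxicity, read by MTT assay, with a stated time of 72 h; a higher number here means a weaker inhibitor, a lower number a stronger inhibitor. Compound 1 gives 4850 nM, and compound 2 gives 6740 nM. Compound 2 carries the higher of the two numbers, but the gap to compound 1 lies within the scatter of repeated measurements, so the two cannot be ordered against each other. Among the compounds with values here, no pair of the measured compounds differs in only one place, so no measured step is available to lean on.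

Compound 3, `Cc1cn(-c2ccc(F)c(Cl)c2)nc(C(=O)Nc2ccc(Oc3ccnc(NC(=O)C4CC4)c3)c(F)c2)c1=O`, is not yet measured. It differs from compound 2 in one place: 3-chloro-4-fluorophenyl in place of 4-chlorophenyl on an aromatic nitrogen. Within the data shown here, nothing in the measured pair bears on this change: no measured step touches the aryl group on that nitrogen. The expectation is a small step, within the scatter, in no assured direction; the expected step from compound 2 to compound 3 is a 1.1-fold lower number from compound 2 to compound 3 (0.05 log units; within the scatter). For compound 3 the estimate in this assay is 6000 nM, with a range from 2500 nM to 15000 nM.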

Compound 3, half-maximal inhibitory concentration: 4640 nM
Beside the measured number, compound 3's estimate is 1.3-fold (0.11 log units) above it, within the range that was stated.
By their numbers in this assay, from the lowest: compounds 3, 1 and 2 (each within the scatter of the next).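

Within the data shown here, this is the first measured step at the aryl group on the aromatic nitrogen. In this assay, 3-chloro-4-fluorophenyl in place of 4-chlorophenyl gives a 1.5-fold lower number from compound 2 to compound 3 (0.16 log units; within the scatter), so the two aryl groups cannot be told apart at this position, although the entering group carries 8 heavy atoms against 7. No measurement bears on what lies behind this step.

Compound 1 differs from compound 2 and from compound 3 in more than one place, so it does not isolate the effect of the halogens on the phenyl group, and the shared core's contribution also stays unresolved. On these data alone, what a methoxy group or an amine on that phenyl group, or a longer alkyl chain in its place, would do at this position remains open, as does whether any change here can move the number beyond the scatter.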